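The source may report more compounds than this note shows. Statements on the series, on what has been measured and on what is new or still open speak of the compounds shown alone.

Measured so far:
compound 1, `O=C(O)/C=C/c1ccc(Cn2ccnc2)cc1OCCc1ccc2ccccc2c1`: in an assay on CHO cells for displacement of a labelled ligand from prostaglandin E2 receptor EP1 subtype (Mus musculus), read by scintillation counting (on this read-out lower numbers stand for stronger inhibition and higher numbers for weaker inhibition), compound 1 gives > 10000 nM, a limit of the assay and not a number.
compound 2, `O=C(O)/C=C/c1ccc(Cc2ccccc2)cc1OCCc1ccc2ccccc2c1`: in this assay compound 2 gives > 10000 nM, likewise a limit.

Compound 2 therefore stands only at a limit. The step that the two limits leave unreadable from compound 1 to compound 2 cannot be read, since both ends rest on (the limit of > 10000 nM in this assay, at which 2 of the 2 values shown sit). Compound 3, `O=C(O)/C=C/c1ccc(COc2ccccc2)cc1OCCc1ccc2ccccc2c1`, differs from compound 2 by phenoxy in place of phenyl on a saturated chain carbon bound to an aromatic carbon. For the measured compounds named here, no measured step bears on this change, so no size or direction can be drawn from the measured pair. The step is expected to be a step that the limit leaves unreadable from compound 2 to compound 3, most likely remaining at the limit. Compound 3 is estimated at 20000 nM, between 5000 nM and 80000 nM.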

Compound 3, inhibition constant: > 10000 nM
Compound 3: a limit, no number; the forecaster's own chance of this, stated with the estimate: 85%; the middle value is on the limit's open side.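

For the compounds shown here, no step between compound 1, compound 2 and compound 3 can be read, since each value is a limit and not a number: the limit of > 10000 nM in this assay, at which 3 of the 3 values shown sit. As far as these compounds go, whether swapping these groups on the saturated chain carbon changes inhibition in this assay stays open.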